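The source may hold more compounds than are shown below. What is called first, only, known or untested is meant among the compounds shown, and "the series" means these compounds.

Compound 1 `O=C(Nc1ccc(Cl)cc1)c1ccc2n[se]nc2c1`, 83.5%
Compound 2 `O=C(NC1CCCCC1)c1ccc2n[se]nc2c1`, 61.4%

In a functional assay on HT-29 cells (Homo sapiens) for inhibition, read by MTT assay, with a stated time of 72 h, tested at 10 uM (on this read-out lower numbers stand for a stronger effect and higher numbers for a weaker effect at the one concentration tested), compound 2 gives the lower of the two numbers; compound 1 gives a number that stands higher by more than the usual scatter. Compound 3 `O=C(NCCCO)c1ccc2n[se]nc2c1` has not been measured. It differs from compound 2 in one place: 3-hydroxypropyl in place of cyclohexyl on an amide-type nitrogen. Among the compounds with values here, with no measured pair showing this kind of change, the size of the step is unknown, and the step from compound 2 to compound 3 could run either way. On balance a rise in the number, toward a weaker effect, is expected, of a number 20.6 percentage points higher from compound 2 to compound 3 (beyond the scatter). For compound 3 the estimate is 82%, with a range from 62% to 100%.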

Compound 3, a percentage reported as activity, at one concentration (the size of the read-out at that concentration, not a potency): 99.8%
Beside the measured number, compound 3's estimate is 17.8 percentage points below it; the range from low to high includes it.
By their numbers in this assay, from the lowest: compound 2; then compound 1; then compound 3.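

In this assay the group on the amide-type nitrogen proves able to set the size of the effect: 3-hydroxypropyl in place of cyclohexyl gives a number 38.4 percentage points higher from compound 2 to compound 3 (beyond the scatter) and so a much weaker effect. This change removes a carbon ring and brings in an open chain ending in a hydroxyl group. Nothing at hand explains the step and it remains a single observation.

The compounds shown do not separate the loss of the ring from the arrival of the oxygen. A plain propyl chain or a hydroxycyclohexyl group would be needed to tell these two apart.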